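This account rests on a few compounds, and the source may have more. Where it says the series, first, only, none or still open, it means among the compounds named here.

Three compounds share a single core and differ only in the groups attached to it. Compound 1 `CCNc1nc(-c2ccccc2)nc2c1nnn2Cc1ccccc1Cl` is measured in an assay on isolated protein for binding affinity to adenosine receptor A1 (Bos taurus) (on this read-out lower numbers stand for stronger inhibition and higher numbers for weaker inhibition), and gives 463000000 nM. In this assay compound 3 `OCCNc1nc(-c2ccccc2)nc2c1nnn2Cc1ccccc1` gives 38000000 nM, and in this assay compound 2 `CCCCNc1nc(-c2ccccc2)nc2c1nnn2Cc1ccccc1F` gives 4300000 nM. Among these three numbers compound 1 stands highest; compound 3 lies nearest to it and compound 2 furthest, and both gaps fall beyond the usual scatter of repeated measurements.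

Compound 4 `COc1ccc(C(=O)Nc2nc(-c3ccccc3)nc3c2nnn3Cc2ccccc2Cl)cc1` has not yet been measured. It differs from compound 1 in one place: (4-methoxyphenyl)carbonyl in place of ethyl on a nitrogen on an aromatic ring. Within the data shown here, no measured pair shows this exchange, and the three measured compounds differ from one another in more than one place, so none of their gaps carries over directly to this change. The exchange is larger than any seen among the measured compounds, and in this assay the expected step is a 7.7-fold lower number from compound 1 to compound 4 (0.89 log units; beyond the scatter), a lowering whose size is uncertain and may or may not exceed the scatter. For compound 4 the estimate in this assay is 60000000 nM, expected to fall between 3000000 nM and 600000000 nM.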

Compound 4, inhibition constant: 20000000 nM
Estimate against measurement, compound 4: 3.0-fold (0.48 log units) above; measured number inside the range.
By their numbers in this assay, from the lowest: compound 2; then compounds 4 and 3 (each within the scatter of the next); then compound 1.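

In this assay, among these compounds, putting (4-methoxyphenyl)carbonyl in place of ethyl on the nitrogen gives a 23-fold lower number from compound 1 to compound 4 (1.36 log units; beyond the scatter), the first change in a single place that can be read. It shows that this nitrogen can carry a much larger group, one that adds a six-membered aromatic ring and a carbonyl, and that the number falls rather than rises with this exchange. Nothing measured here accounts for the size or direction of this step.

The compounds shown leave open whether the carbonyl or the 4-methoxyphenyl part carries the step, which an acetyl or an unsubstituted benzoyl group on the same nitrogen would separate. They also leave open whether the exchange gives a similar step when a fluorine or a hydrogen stands in place of the chlorine.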